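A few compounds are considered here, and "the series" means these few. Any claim that something is new, unique, unknown or untested is made for them only; others in the source may bear on it.

Compound 2 `O=C(CCCN1CCN(c2ccccc2Cl)CC1)Nc1ccc(Cl)cc1` gives 6010 nM in an assay on HEK293 cells for inhibition of Voltage-dependent T-type calcium channel subunit alpha-1G (Homo sapiens), read by patch clamp (on this read-out lower numbers stand for stronger inhibition and higher numbers for weaker inhibition), the higher of the two numbers measured, although its distance from compound 1 `O=C(CCCN1CCN(c2ccc(F)cc2)CC1)Nc1ccc(Cl)cc1`, which gives 3490 nM, lies within the scatter: the step from compound 1 to compound 2 is a 1.7-fold higher number from compound 1 to compound 2 (0.24 log units; within the scatter). Compound 3 `O=C(CCCN1CCN(c2ccc(Cl)cc2)CC1)Nc1ccc(Cl)cc1` differs from compound 2 by 4-chlorophenyl in place of 2-chlorophenyl on an amine nitrogen in a ring. Going by the values given here, the only measured step that bears on such an exchange of aryl groups on this ring nitrogen is a 1.7-fold higher number from compound 1 to compound 2 (0.24 log units; within the scatter), which stayed within the scatter, so no step beyond the scatter is expected in this assay here either. Compound 3 is therefore estimated at 4000 nM, with a range of 1500 nM to 11000 nM, an expected step of a 1.5-fold lower number from compound 2 to compound 3 (0.18 log units; within the scatter).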

Compound 3, half-maximal inhibitory concentration: 2640 nM
Compound 3: the middle estimate sits 1.5-fold (0.18 log units) above what was measured; the range from low to high includes it.
By their numbers in this assay, from the lowest: compounds 3, 1 and 2 (each within the scatter of the next, the first and the last beyond it).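

In this assay, 4-chlorophenyl in place of 2-chlorophenyl gives a 2.3-fold lower number from compound 2 to compound 3 (0.36 log units; beyond the scatter) and is the only step among these three compounds beyond the scatter, so where the chlorine sits on this phenyl group has a modest bearing on the number. Chloro in place of fluoro gives a 1.3-fold lower number from compound 1 to compound 3 (0.12 log units; within the scatter) and stays within the scatter. Nothing measured here gives a reason for either step. The compounds shown leave open how a methoxy group, a trifluoromethyl group or a pyridine ring would read on this ring nitrogen.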